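The source may hold more compounds than are shown below. What is called first, only, known or untested is meant among the compounds shown, and "the series" means these compounds.

In a functional assay on A549 cells (Homo sapiens) for inhibition, read by MTT assay (on this read-out lower numbers stand for stronger inhibition and higher numbers for weaker inhibition), compound 1 (`N#Cc1c(N)sc(C(=O)Nc2ccc(Cl)cc2)c1-c1ccccc1`) gives 700 nM and compound 2 (`CCOC(=O)c1c(NC(=O)CC#N)sc(C(=O)Nc2ccc(Cl)cc2)c1-c1ccccc1`) gives 600 nM so the two stand within the usual scatter of each other. Compound 3 (`CCOC(=O)c1c(N)sc(C(=O)Nc2ccc(Cl)cc2)c1-c1ccccc1`) has yet to be measured. It differs from compound 2 by hydrogen in place of (cyanomethyl)carbonyl on a nitrogen on an aromatic ring with hydrogen in place of (cyanomethyl)carbonyl on a nitrogen on an aromatic ring. Within the data shown here, no measured pair shows this change alone, so the data give no direct size for it. Among the measured compounds shown here, compound 3 keeps an ester where compound 1 has a nitrile, but both carry the free amino group, and compound 1 gives 700 nM as the only guide. In this assay the expected change is a 1.3-fold higher number from compound 2 to compound 3 (0.12 log units; within the scatter) and so a small move toward a higher number that may stay within the scatter. For compound 3 the estimated value is 800 nM with an expected range from 250 nM to 2500 nM as the likely span.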

Compound 3, half-maximal inhibitory concentration: 230 nM
The estimate for compound 3 lay 3.5-fold (0.54 log units) above the measured number; the measured number lies below the stated range.
By their numbers in this assay, from the lowest: compound 3; then compounds 2 and 1 (each within the scatter of the next).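

In this assay, hydrogen in place of (cyanomethyl)carbonyl on the nitrogen, with the ester kept, gives a 2.6-fold lower number from compound 2 to compound 3 (0.42 log units; beyond the scatter), so this position responds to the change once it is read alone. With the free amino group kept, ethoxycarbonyl in place of cyano on the aromatic carbon gives a 3.0-fold lower number from compound 1 to compound 3 (0.48 log units; beyond the scatter), which makes compound 3 the most potent of the three, as both of its steps lie beyond the scatter. Nothing available explains the size of either step.

Going by these compounds, it remains open whether a smaller acyl group such as acetyl on this nitrogen would read closer to compound 2 or to compound 3. Also open, on these data alone, is how a carboxylic acid or a primary amide would compare with the ethyl ester of compound 3 on the aromatic carbon.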